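Adding One Methyl to a Methoxy Group

This account rests on a few compounds, and the source may have more. Where it says the series, first, only, none or still open, it means among the compounds named here.

In a functional assay on HeLa cells (Homo sapiens) for inhibition, read by MTT assay, with a stated time of 72 h (a lower number here means a stronger inhibitor, a higher number a weaker inhibitor), compound 1 `C=C(Br)C(=O)Nc1cccc(/C=C/C(=O)Nc2ccccc2)c1` gives 7300 nM, compound 2 `C=C(Br)C(=O)Nc1cccc(/C=C/C(=O)Nc2ccc(Cl)cc2)c1` gives 2800 nM, and compound 3 `C=C(Br)C(=O)Nc1cccc(/C=C/C(=O)Nc2ccc(OC)cc2)c1` gives 790 nM, the lowest of the three numbers. Compound 4 `C=C(Br)C(=O)Nc1cccc(/C=C/C(=O)Nc2ccc(OCC)cc2)c1` differs from compound 3 by methyl in place of hydrogen on a saturated chain carbon bound to an oxygen on an aromatic ring, turning methoxy into ethoxy. The closest evidence is a 9.2-fold lower number from compound 1 to compound 3 (0.97 log units; beyond the scatter), methoxy in place of hydrogen, and a 3.5-fold lower number from compound 2 to compound 3 (0.55 log units; beyond the scatter), methoxy in place of chloro, while a 2.6-fold lower number from compound 1 to compound 2 (0.42 log units; beyond the scatter) brings chloro in place of hydrogen. All three change the group on an aromatic carbon, and none adds methyl to the saturated chain carbon, so no step beyond the scatter is expected in this assay. The expected change is a 1.1-fold higher number from compound 3 to compound 4 (0.06 log units; within the scatter). Compound 4 is estimated at 900 nM, within a range of 350 nM to 2300 nM.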

Compound 4, half-maximal inhibitory concentration: 2000 nM
For compound 4 the middle estimate is 2.2-fold (0.35 log units) below the measured one; measured number inside the range.
By their numbers in this assay, from the lowest: compound 3; then compounds 4 and 2 (each within the scatter of the next); then compound 1.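

In this assay, this saturated chain carbon proves sensitive to a single added methyl (a 2.5-fold higher number from compound 3 to compound 4 (0.40 log units; beyond the scatter)), so the benefit of methoxy does not simply carry over to ethoxy. Ethoxy still keeps an advantage over hydrogen on the aromatic carbon (a 3.7-fold lower number from compound 1 to compound 4 (0.56 log units; beyond the scatter)), but it cannot be told apart from chloro (a 1.4-fold lower number from compound 2 to compound 4 (0.15 log units; within the scatter)). The compounds shown leave open whether a longer chain such as propoxy or a hydroxyl group in place of methoxy would follow the same direction. No measurement offered here explains the step.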